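Shortening the alkoxy chain on the shared core

This account rests on a few compounds, and the source may have more. Where it says the series, first, only, none or still open, it means among the compounds named here.

Compound 1 `CCCCCCOc1ccc2c(Cl)ccnc2c1` and compound 2 `Clc1ccnc2cc(OCCCc3ccccc3)ccc12` share one core and differ only in the chain on the aromatic oxygen. Among the measured compounds shown here, in a functional assay on RKO cells (Homo sapiens) for cytotoxicity, read by MTT assay, with a stated time of 48 h (on this read-out higher numbers stand for weaker inhibition and lower numbers for stronger inhibition), compound 1 gives 2720 nM and compound 2 gives 1420 nM; the single step, a 1.9-fold lower number from compound 1 to compound 2 (0.28 log units; within the scatter), is within the scatter. Compound 1 therefore stands as the higher of the two numbers, but not separated from compound 2.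

Compound 3 `C=CCOc1ccc2c(Cl)ccnc2c1` is not yet measured. It differs from compound 1 as follows: vinyl in place of pentyl on a saturated chain carbon bound to an oxygen on an aromatic ring. For the measured compounds named here, the only measured step exchanges phenyl for propyl at the far end of the chain and does not touch the chain length near the oxygen, so it bears on this change only indirectly, and it was within the scatter. No step beyond the scatter is therefore expected, a 1.5-fold higher number from compound 1 to compound 3 (0.17 log units; within the scatter), with wide uncertainty. Compound 3 is estimated at 4000 nM, within a range of 1500 nM to 12000 nM.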

Compound 3, half-maximal inhibitory concentration: 2460 nM
The estimate for compound 3 lay 1.6-fold (0.21 log units) above the measured number, and the stated range covers the measured number.
By their numbers in this assay, from the lowest: compounds 2, 3 and 1 (each within the scatter of the next).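

In this assay, allyl on the aromatic oxygen in place of hexyl leaves the number within the scatter (a 1.1-fold lower number from compound 1 to compound 3 (0.04 log units; within the scatter)). The earlier step covered only phenyl in place of propyl, whereas this one shows that the chain can go from pentyl, with 5 heavy atoms, to vinyl, with 2 heavy atoms and a double bond, without separating the two compounds in this assay. Nothing on hand offers a reason for this result.

The compounds shown leave open whether an amine or a carboxylic acid at the end of this chain, or a chain longer than hexyl, would give a number beyond the scatter. Also open, on these data alone, is whether a saturated propyl chain would read like allyl, which would show whether the double bond matters here.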